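Moving the iodine on the benzamide of compound 3

The source may report more compounds than this note shows. Statements on the series, on what has been measured and on what is new or still open speak of the compounds shown alone.

Compound 3 `O=C(Nc1ccc(Oc2cc(C(F)(F)F)cc(C(F)(F)F)c2)cc1)c1cc(I)ccc1F` stands in an assay on HEK293 cells for inhibition of Toll-like receptor 8 (Homo sapiens), with a stated time of 16 h (a higher number here means a weaker inhibitor, a lower number a stronger inhibitor), as "not determined" (no result reported), so no number is available for it. Of its neighbours, compound 1 `Fc1cccc(Cl)c1CNc1ccc(Oc2cc(C(F)(F)F)cc(C(F)(F)F)c2)cc1` sits at a limit of the assay, > 50000 nM, which is a limit and not a number. Compound 2 `O=C(Nc1ccc(Oc2cc(C(F)(F)F)cc(C(F)(F)F)c2)cc1)c1c(F)cccc1Br` gives 6000 nM in this assay. Within the data shown here, the one measured step, an at least 8.3-fold lower number from compound 1 to compound 2 (0.92 log units; beyond the scatter), replaces the group on the ring nitrogen and so concerns a different part of the molecule; it does not bear on the change to compound 4 `O=C(Nc1ccc(Oc2cc(C(F)(F)F)cc(C(F)(F)F)c2)cc1)c1ccc(I)cc1F`, which is 2-fluoro-4-iodophenyl in place of 2-fluoro-5-iodophenyl on a carbonyl carbon. Among the measured compounds shown here, no measured step in this assay touches the iodine-bearing ring, so no direction beyond the scatter can be argued from the data. Compound 4 is therefore expected, by analogy with compound 2 in this assay, to give about 6000 nM, within 1500 nM to 30000 nM.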

Compound 4, half-maximal inhibitory concentration: > 50000 nM
Compound 4: only a limit was reported; the forecaster's own chance of this, stated with the estimate: 25%; at least 8.3-fold (0.92 log units) between middle value and limit.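

A change on the ring attached to the carbonyl carbon now has a size: an at least 8.3-fold higher number from compound 2 to compound 4 (0.92 log units; beyond the scatter), so in this assay this ring, and not only the group on the nitrogen, moves the read-out. Compound 4 gives > 50000 nM, which is a limit of the assay and not a number. The step from compound 1 to compound 4 cannot be read, and the same limit recurs: the limit of > 50000 nM in this assay, at which 2 of the 4 values shown sit.

As far as these compounds go, compound 3 has no result, and the effect of moving the iodine alone stays open. Also open, from the compounds shown here alone, is how a nitrile or a methoxy group in place of the iodine would read.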